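Sulfide with Relocated Acid: Expected Receptor Binding

A few compounds are considered here, and "the series" means these few. Any claim that something is new, unique, unknown or untested is made for them only; others in the source may bear on it.

Measured compounds:
compound 1 `COc1ccc(CCCCCCCCOc2ccc(C[S+]([O-])c3cccc(C(=O)O)c3)nc2/C=C/C(=O)O)cc1` — 167 nM
compound 2 `COc1ccc(CCCCCCCCOc2ccc(C[S+]([O-])Cc3cccc(C(=O)O)c3)nc2/C=C/C(=O)O)cc1` — 240 nM
compound 3 `COc1ccc(CCCCCCCCOc2ccc(CS(=O)(=O)Cc3cccc(C(=O)O)c3)nc2/C=C/C(=O)O)cc1` — 53 nM

All three were tested in an assay on isolated protein for displacement of a labelled ligand from leukotriene B4 receptor 1 (Homo sapiens); on this read-out lower numbers stand for stronger inhibition and higher numbers for weaker inhibition. Compound 2 gives the highest number of the three in this assay, though its gap to compound 1 is within the scatter, as the step of a 1.4-fold higher number from compound 1 to compound 2 (0.16 log units; within the scatter) shows; only compound 3 stands clearly apart, with a number well below that of compound 2.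

The new compound 4 `COc1ccc(CCCCCCCCOc2ccc(CSCc3ccc(C(=O)O)cc3)nc2/C=C/C(=O)O)cc1` differs from compound 2 in the following way: a group of 11 heavy atoms (8 carbon, 2 oxygen, 1 sulfur; one six-membered aromatic ring of carbon only) in place of a group of 12 heavy atoms (8 carbon, 3 oxygen, 1 sulfur; one six-membered aromatic ring of carbon only), on a saturated chain carbon bound to an aromatic carbon. This change does two things at once: the sulfur loses its oxygen, and the carboxylic acid sits on a different carbon of the benzyl ring. Going by the values given here, no measured step covers either of these alterations. Among the compounds with values here, the one step that is known, from compound 1 to compound 2, concerns the carboxyphenyl versus carboxybenzyl group and was within the scatter, so it says little about compound 4. Compounds 2 and 3 show that changing the oxygen count on the sulfur can matter, but the direction for a sulfide is not established.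

Within the data shown here, with no direct precedent, compound 4 is expected to land near compound 2, with a step of a 1.2-fold lower number from compound 2 to compound 4 (0.08 log units; within the scatter), giving an estimated 200 nM, ranging from 50 nM to 800 nM.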

Compound 4, inhibition constant: 5.7 nM
Beside the measured number, compound 4's estimate is 35-fold (1.55 log units) above it; the whole stated range lies above it.
By their numbers in this assay, from the lowest: compound 4; then compound 3; then compounds 1 and 2 (each within the scatter of the next).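

In this assay, the group on the saturated chain carbon bound to an aromatic carbon proves able to shift the number a long way: the (4-carboxybenzyl)sulfanyl group gives a 42-fold lower number from compound 2 to compound 4 (1.62 log units; beyond the scatter) and a 29-fold lower number from compound 1 to compound 4 (1.47 log units; beyond the scatter). The earlier replacement at this place, a 1.4-fold higher number from compound 1 to compound 2 (0.16 log units; within the scatter), gave no sign of a change this large. Compound 4 alone has a sulfur without oxygen and a 4-carboxybenzyl group, so these two differences arrive together and their shares of the step cannot be separated, and nothing available accounts for the size of the gain.

From the compounds shown here alone, it remains open whether the loss of oxygen from the sulfur, the new place of the carboxylic acid, or the two in combination produce the step, a question that a compound bearing the (3-carboxybenzyl)sulfanyl group could help to settle. Also open, going by these compounds, is whether the sulfur itself matters, which could be tested by an ether oxygen or a methylene group in its place.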